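Amine chain variation on a shared dinitrile core

The source may report more compounds than this note shows. Statements on the series, on what has been measured and on what is new or still open speak of the compounds shown alone.

Compound 1 `CCN(CC)CCn1c(N)c(-c2nc3ccccc3[nH]2)c2nc(C#N)c(C#N)nc21` gives > 50000 nM in a functional assay on A549 cells (Homo sapiens) for antiproliferative activity, read by MTT assay, with a stated time of 48 h (a higher number here means a weaker inhibitor, a lower number a stronger inhibitor), a limit of the assay.
Compound 2 `CN(C)CCCn1c(N)c(-c2nc3ccccc3[nH]2)c2nc(C#N)c(C#N)nc21` gives 10400 nM in this assay.
Compound 3 `CCN(CC)CCCn1c(N)c(-c2nc3ccccc3n2C)c2nc(C#N)c(C#N)nc21` gives 10700 nM in this assay.

Compound 1 to compound 2 is (dimethylamino)methyl in place of diethylamino on a saturated chain carbon, two bonds along the chain from an aromatic nitrogen. This brought an at least 4.8-fold lower number from compound 1 to compound 2 (0.68 log units; beyond the scatter), with compound 1 resting at the limit of > 50000 nM in this assay, at which 1 of the 3 values shown sits. The difference between the cores of compound 1 and compound 3 is not broken down here. Compound 2 and compound 3 give numbers within the usual scatter of each other.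

Compound 4 `CN(C)CCCCn1c(N)c(-c2nc3ccccc3n2C)c2nc(C#N)c(C#N)nc21` is not yet measured. It differs from compound 3 by (dimethylamino)methyl in place of diethylamino on a saturated chain carbon, three bonds along the chain from an aromatic nitrogen. This is the same kind of change as from compound 1 to compound 2, but the place differs: three bonds along the chain from an aromatic nitrogen rather than two. Compound 4 is expected to give 6000 nM. Its expected range runs from 2500 nM to 15000 nM. The expected step is a 1.8-fold lower number from compound 3 to compound 4 (0.25 log units; within the scatter), kept smaller because the place of the change differs from that of an at least 4.8-fold lower number from compound 1 to compound 2 (0.68 log units; beyond the scatter).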

Compound 4, half-maximal inhibitory concentration: 6150 nM
The estimate for compound 4 lay 1.0-fold (0.01 log units) below the measured number; the measured number falls inside the stated range.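

Carried to a second core in this assay, the change gave a 1.7-fold lower number from compound 3 to compound 4 (0.24 log units; within the scatter) and did not keep the size of the earlier step: the same change on two cores in this assay, an at least 4.8-fold lower number (0.68 log units; beyond the scatter) from compound 1 to compound 2 and a 1.7-fold lower number (0.24 log units; within the scatter) from compound 3 to compound 4, at least 2.7-fold (0.44 log units) apart, beyond the scatter of two such steps.
Compound 1 gives > 50000 nM, which is a limit of the assay and not a number.
Among these compounds, with only one pair on each core, the comparison shows that the step depends on its setting, but it does not show whether the chain or some other part of the core accounts for the gap.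

The compounds shown leave open how a ring amine such as morpholine or piperidine at the chain end would behave. They also leave open how a longer chain would behave on either core.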